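Replacing hydroxy with 1-ethoxyethenyl on compound 3

The source may hold more compounds than are shown below. What is called first, only, known or untested is meant among the compounds shown, and "the series" means these compounds.

Measured compounds:
compound 1 `O=C1CCC(N2C(=O)c3cccc(Nc4ccccn4)c3C2=O)C(=O)N1`: 1%
compound 2 `Cc1ccccc1Nc1cccc2c1C(=O)N(C1CCC(=O)NC1=O)C2=O`: 7%
compound 3 `O=C1CCC(N2C(=O)c3cccc(Nc4ccc(O)cc4)c3C2=O)C(=O)N1`: 4%

In an assay on FRT-Jurkat cells for inhibition of nuclear factor NF-kappa-B complex (Homo sapiens), read by flow cytometry, with a stated time of 24 h, tested at 10 uM (a lower number here means less inhibition, a higher number more inhibition at the concentration tested (going by the name of the read-out)), all three measured compounds give low numbers. Compound 3 stands second highest of the three, and its steps to its neighbours, a number 3 percentage points higher from compound 1 to compound 3 (within the scatter) and a number 3 percentage points lower from compound 2 to compound 3 (within the scatter), both lie within the scatter, as does a number 6 percentage points higher from compound 1 to compound 2 (within the scatter). Compound 4 `C=C(OCC)c1ccc(Nc2cccc3c2C(=O)N(C2CCC(=O)NC2=O)C3=O)cc1` differs from compound 3 in one place: 1-ethoxyethenyl in place of hydroxy on an aromatic carbon. Among the measured compounds shown here, no measured step exchanges these two groups. The steps that do vary the group on the nitrogen on the aromatic ring all stay within the scatter, so for compound 4 no step beyond the scatter is expected in this assay. Compound 4 is therefore estimated at 5%, with a range from -6% to 16%. This estimate means an expected step of a number 1 percentage points higher from compound 3 to compound 4 (within the scatter).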

Compound 4, a percentage reported as inhibition, at one concentration (the size of the read-out at that concentration, not a potency): 10%
Compound 4: middle estimate off by 5 percentage points, on the low side, and the stated range covers the measured number.
By their numbers in this assay, from the lowest: compounds 1, 3, 2 and 4 (each within the scatter of the next).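

In this assay, putting 1-ethoxyethenyl in place of hydroxy on the aromatic carbon para to a large group gives a number 6 percentage points higher from compound 3 to compound 4 (within the scatter). This position therefore accepts a group of 5 heavy atoms with no hydrogen-bond donor, and the read-out stays within the scatter. The earlier steps shown here exchanged the whole group on the nitrogen, whereas this one alters only a substituent on that ring, and no other measurement bears on the result. From the compounds shown here alone, whether an amine or a carboxylic acid here would produce a step beyond the scatter remains open.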